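A few compounds are considered here, and "the series" means these few. Any claim that something is new, unique, unknown or untested is made for them only; others in the source may bear on it.

Working notes on the series.

The shared core carries an imine link to a substituted phenyl ring; compound 1 `COc1ccc(/C=N/c2c(C)n(C)n(-c3ccccc3)c2=O)cc1` bears a methoxy on that ring, compound 2 `COc1ccc(/C=N/c2c(C)n(C)n(-c3ccccc3)c2=O)cc1OC` a second methoxy, and compound 3 `COc1cc(/C=N/c2c(C)n(C)n(-c3ccccc3)c2=O)ccc1O` a hydroxy in place of one methyl on oxygen. In a functional assay on DLD-1 cells (Homo sapiens) for cytotoxicity, read by MTT assay, with a stated time of 72 h (a higher number here means a weaker inhibitor, a lower number a stronger inhibitor), compound 1 gives 977000000 nM, compound 2 gives 676000000 nM, and compound 3 gives 759000000 nM. The three numbers sit within the scatter of one another, so compound 1 is not set apart from compound 2 or compound 3 by what is measured. The step of a 1.4-fold lower number from compound 1 to compound 2 (0.16 log units; within the scatter) and the step of a 1.1-fold higher number from compound 2 to compound 3 (0.05 log units; within the scatter) are both inside the scatter: changing the substitution of this phenyl ring has so far moved nothing.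

Compound 4 `Cc1c(/N=C/c2ccc(Cl)cc2)c(=O)n(-c2ccccc2)n1C` differs from compound 1 by chloro in place of methoxy on an aromatic carbon. Among the compounds with values here, no measured step exchanges one group for another at this position, so the nearest guide is that the two changes on the same ring left the read-out flat. On that basis no step beyond the scatter is expected in this assay, in either direction. For compound 4 the value is estimated at 977000000 nM, with a range from 400000000 nM to 2400000000 nM. The expected step of no change at the digits printed from compound 1 to compound 4 (within the scatter) is therefore taken as essentially nil.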

Compound 4, half-maximal inhibitory concentration: 631000000 nM
Compound 4: middle estimate off by 1.5-fold (0.19 log units), on the high side; measured number inside the range.
By their numbers in this assay, from the lowest: compounds 4, 2, 3 and 1 (each within the scatter of the next).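

In this assay, replacing the 4-methoxyphenyl with the 4-chlorophenyl gives a 1.5-fold lower number from compound 1 to compound 4 (0.19 log units; within the scatter). Within the data shown here, this is the first exchange of one group for another at this place, para to a large group, whereas the earlier steps changed other places on the same ring, and it too stays inside the scatter. The methoxy and its hydrogen-bond acceptor can therefore give way to chloro here without the read-out separating from that of the methoxy compound, and nothing available bears on why the read-out stays flat.

Still open, going by these compounds, is whether any group at this position can move the number beyond the scatter, for example an amine, a carboxylic acid or a longer chain. Also open, on these data alone, is whether a change on the shared core, away from this ring, would shift the read-out.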